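Swapping Methyl for Nitro on a Shared Core

A few compounds are considered here, and "the series" means these few. Any claim that something is new, unique, unknown or untested is made for them only; others in the source may bear on it.

Of the compounds shown here, two of a shared core have been measured in a toxicity assay on the whole organism with Rattus norvegicus as the target, at a dose of 100 mg/kg by the oral route; a lower number here means a weaker effect, a higher number a stronger effect of the compound at the dose given. Compound 1 `Cc1cc(OCC2=NCCO2)ccc1Cl` gives 20% in this assay, and compound 2 `Cc1cccc(OCC2=NCCO2)c1` gives 15%. Among the measured compounds shown here, the only measured step between them, a number 5 percentage points lower from compound 1 to compound 2 (within the scatter), leaves the two numbers within the scatter, so compound 2 stands at one of two numbers that cannot be told apart from each other, and nothing yet sets it apart from compound 1.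

Compound 3 `O=[N+]([O-])c1cccc(OCC2=NCCO2)c1` is not yet measured. It differs from compound 2 by nitro in place of methyl on an aromatic carbon. For the measured compounds named here, no measured step concerns a nitro group, and the one step in hand, hydrogen in place of chloro on an aromatic carbon, was itself within the scatter. The data therefore give no ground to expect a change beyond the scatter from nitro in place of methyl. Compound 3 is accordingly expected to stay close to compound 2, with the expected step of a number 3 percentage points higher from compound 2 to compound 3 (within the scatter). Going by the values given here, the estimate for compound 3 in this assay is 18%, ranging from 5% to 40%, a wide range because only the single step of a number 5 percentage points lower from compound 1 to compound 2 (within the scatter) is available to guide it.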

Compound 3, a percentage reported as activity, at one dose (the size of the read-out at that dose, not a potency): 45%
The estimate for compound 3 lay 27 percentage points below the measured number; measured number above the stated range.
By their numbers in this assay, from the lowest: compounds 2 and 1 (each within the scatter of the next); then compound 3.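

In this assay, the place on the aromatic carbon meta to a group of 7 heavy atoms proves able to shift the read-out: nitro in place of methyl there gives a number 30 percentage points higher from compound 2 to compound 3 (beyond the scatter), the only step shown that lies beyond the scatter. The earlier step, hydrogen in place of chloro on an aromatic carbon, had left open whether a single replacement on this aromatic ring could move the number at all, and this step shows that one can. No measurement available here bears on why this replacement gives such a step.

On these data alone, it remains open whether the rise belongs to nitro specifically or would also appear with another group at this place, such as an amine, a nitrile or a carboxylic acid. As far as these compounds go, it is equally open whether nitro would give a similar step at another place on the aromatic ring, or with the chloro of compound 1 also present on the shared core.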